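This account rests on a few compounds, and the source may have more. Where it says the series, first, only, none or still open, it means among the compounds named here.

Measured in a functional assay on PC-3 cells (Homo sapiens) for inhibition, read by MTT assay, with a stated time of 48 h; on this read-out higher numbers stand for weaker inhibition and lower numbers for stronger inhibition:
- compound 1 `CCSc1nnc(-c2cc(OC)c(OC)c(OC)c2)n1-c1ccc(N(C)C)cc1`: 46200 nM
- compound 2 `COc1cc(-c2nnc(SCC(=O)C3CC3)n2-c2ccc(N(C)C)cc2)cc(OC)c1OC`: 45900 nM

Compound 2, at 45900 nM, stands level with compound 1, the two values lying within the scatter of each other. The next compound, compound 3 `COc1ccc(NC(=O)CSc2nnc(-c3cc(OC)c(OC)c(OC)c3)n2-c2ccc(N(C)C)cc2)cc1`, has (4-methoxyphenyl)amino in place of cyclopropyl on a carbonyl carbon. Going by the values given here, the one measured step that bears on this change is a 1.0-fold lower number from compound 1 to compound 2 (0.00 log units; within the scatter), which also altered the group at this end of the molecule. Among the compounds with values here, no measured compound carries (4-methoxyphenyl)amino, so this single step is a thin guide. On that evidence, no step beyond the scatter is expected in this assay, and the range is kept wide. The estimated change is a 1.5-fold lower number from compound 2 to compound 3 (0.18 log units; within the scatter). For compound 3 the expected value is 30000 nM, within an estimated range from 8000 nM to 75000 nM.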

Compound 3, half-maximal inhibitory concentration: 56100 nM
For compound 3 the middle estimate is 1.9-fold (0.27 log units) below the measured one; the range from low to high includes it.
By their numbers in this assay, from the lowest: compounds 2, 1 and 3 (each within the scatter of the next).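

In this assay, placing (4-methoxyphenyl)amino in place of cyclopropyl on the carbonyl carbon gives a 1.2-fold higher number from compound 2 to compound 3 (0.09 log units; within the scatter), and the comparison with the simple chain gives a 1.2-fold higher number from compound 1 to compound 3 (0.08 log units; within the scatter). This end of the molecule has therefore now carried a six-membered aromatic ring and a hydrogen-bond donor, neither of which appears in the two earlier compounds, and all three compounds remain level within the scatter. Nothing available explains why the values stay level.

The compounds shown leave open whether any group at this end can move the number beyond the scatter, such as a carboxylic acid or a basic amine on the chain bound to the sulfur. They also leave open whether a chloro group in place of the methoxy on the phenyl ring would change the picture.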